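Swapping the aromatic amide group on a glycine transporter inhibitor

This account rests on a few compounds, and the source may have more. Where it says the series, first, only, none or still open, it means among the compounds named here.

Measured compounds:
- compound 1, `CCCS(=O)(=O)N1CCC(CNC(=O)C2CC2)(C(=O)N2CCOCC2)CC1`: > 5000 nM
- compound 2, `CCCS(=O)(=O)N1CCC(CNC(=O)c2ccc(F)cc2C(F)(F)F)(C(=O)N2CCOCC2)CC1`: 67.8 nM
- compound 3, `CCCS(=O)(=O)N1CCC(CNC(=O)c2ccc(Cl)cc2Cl)(C(=O)N2CC(N)C2)CC1`: 109 nM

All three compounds share one core and differ in the group on the amide carbonyl. In an assay on isolated protein for inhibition of sodium- and chloride-dependent glycine transporter 1 (Homo sapiens) (on this read-out lower numbers stand for stronger inhibition and higher numbers for weaker inhibition), compound 1 gives only a limit, > 5000 nM, which is the limit noted as the limit of > 5000 nM in this assay, at which 1 of the 3 values shown sits. Compound 2 gives 67.8 nM in this assay, the lowest number among the measured values; compound 3 gives 109 nM, and these two values lie within the scatter of each other. Among the measured compounds shown here, the one measured step is an at least 73-fold lower number from compound 1 to compound 2 (1.86 log units; beyond the scatter), so replacing cyclopropyl with a substituted six-membered aromatic ring made a large difference.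

Compound 4, `CCCS(=O)(=O)N1CCC(CNC(=O)c2c(F)ccc(Cl)c2F)(C(=O)N2CCOCC2)CC1`, keeps the core of compound 2 and changes only the aromatic group: 3-chloro-2,6-difluorophenyl in place of 4-fluoro-2-(trifluoromethyl)phenyl on a carbonyl carbon. The step from compound 1 to compound 2 bears on it only loosely, since compound 4 retains a six-membered aromatic ring of carbon with halogen substituents, as compound 3 also does. A step no larger than the scatter is therefore expected, as a 1.8-fold higher number from compound 2 to compound 4 (0.25 log units; within the scatter), and compound 4 is estimated at 120 nM, between 40 nM and 400 nM.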

Compound 4, half-maximal inhibitory concentration: 8.4 nM
Compound 4: middle estimate off by 14-fold (1.15 log units), on the high side; measured number below the stated range.
By their numbers in this assay, from the lowest: compound 4; then compounds 2 and 3 (each within the scatter of the next). At a limit, above all of these: compound 1.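

Putting 3-chloro-2,6-difluorophenyl on the carbonyl carbon gives an 8.1-fold lower number from compound 2 to compound 4 (0.91 log units; beyond the scatter), so the halogen pattern on the aromatic ring matters here, and having such a ring is not enough: both groups contain one six-membered aromatic ring of carbon only, with no hydrogen-bond donors or acceptors. Measured against the cyclopropyl amide, the new group gives an at least 590-fold lower number from compound 1 to compound 4 (2.77 log units; beyond the scatter). That step gives only a minimum size, because compound 1 stands at a limit: the limit of > 5000 nM in this assay, at which 1 of the 4 values shown sits.

The two aromatic groups differ in several substituents at once, so these compounds cannot show whether the chlorine, the two fluorines or the loss of trifluoromethyl accounts for the lower number. On these data alone, how a nitrile or a methoxy group would compare on this ring also remains open.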